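Fluoro to methyl at a growth-inhibiting compound

The source may hold more compounds than are shown below. What is called first, only, known or untested is meant among the compounds shown, and "the series" means these compounds.

Compound 1 `Cc1cc(-c2nc3c(F)cccc3s2)ccc1N`: 5500 nM
Compound 2 `Nc1ccc(-c2nc3ccccc3s2)cc1F`: < 10 nM (a limit)

Both values come from a functional assay on NCI-H226 cells (Homo sapiens) for inhibition; on this read-out lower numbers stand for stronger inhibition of growth and higher numbers for weaker inhibition of growth. For compound 2, the reading of < 10 nM is a limit of the assay and not a number. Compound 3 `Cc1cc(-c2nc3ccccc3s2)ccc1N` differs from compound 2 in one place, with methyl in place of fluoro on an aromatic carbon, ortho to an amino group (methyl in place of fluoro on an aromatic carbon). For the measured compounds named here, no measured step shows this change directly. A small move towards weaker inhibition of growth is expected in this assay, possibly none beyond the scatter. Compound 1 reads 5500 nM in this assay, and with that value in view the expected range stays wide on its upper side. The estimated change is a step that the limit leaves unreadable from compound 2 to compound 3 in size. Compound 3 is expected to read 8 nM, with an estimated range from 1 nM to 200 nM on this read-out.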

Compound 3, concentration for 50% growth inhibition: 18600 nM
Beside the measured number, compound 3's estimate is 2300-fold (3.37 log units) below it, and the stated range ends below it.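

In this assay, methyl in place of fluoro on an aromatic carbon, ortho to an amino group, proves to be a very large change rather than a minor one, with an at least 1800-fold higher number from compound 2 to compound 3 (3.26 log units; beyond the scatter). The full size of that step cannot be read, because compound 2 stands at a limit of the assay and not at a number: the limit of < 10 nM in this assay, at which 1 of the 3 values shown sits. The other change now readable, the removal of a fluoro group, is far smaller, with a 3.4-fold higher number from compound 1 to compound 3 (0.53 log units; beyond the scatter).

On these data alone, whether a chlorine, a methoxy group or a plain hydrogen at this position would read close to compound 2 or close to compound 3 stays open. Also open, as far as these compounds go, is whether the large step depends on methyl entering or on fluoro leaving.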